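This account rests on a few compounds, and the source may have more. Where it says the series, first, only, none or still open, it means among the compounds named here.

The measured compounds are compound 1 `ClCc1ccccc1Cn1cnc2c(Cl)nc(Cl)nc21` giving 2230 nM, compound 2 `ClCc1cccc(Cn2cnc3c(Cl)nc(Cl)nc32)c1` giving 3090 nM, and compound 3 `Nc1nc(Cl)c2ncn(Cc3ccccc3CCl)c2n1` giving 21900 nM, all in a functional assay on A549 cells (Homo sapiens) for cytotoxicity, read by sulforhodamine B assay, with a stated time of 48 h; on this read-out lower numbers stand for stronger inhibition of growth and higher numbers for weaker inhibition of growth.

Compound 2 and compound 1 are built from the same atoms joined differently; the difference between the two cores is not broken down here. Their numbers in this assay lie within the usual scatter of each other. Compound 3 differs from compound 1 by one change, (amino in place of chloro on an aromatic carbon), and that change made the step of a 9.8-fold higher number from compound 1 to compound 3 (0.99 log units; beyond the scatter). Compound 4 `Nc1nc(Cl)c2ncn(Cc3cccc(CCl)c3)c2n1` is not yet measured; it stands to compound 2 as compound 3 stands to compound 1, through the same change, (amino in place of chloro on an aromatic carbon). Going by the values given here, a step of about the same size is expected in this assay because compound 2 gives 3090 nM and the earlier step of a 9.8-fold higher number from compound 1 to compound 3 (0.99 log units; beyond the scatter) is the only guide. Through this change the expected step is a 9.1-fold higher number from compound 2 to compound 4 (0.96 log units; beyond the scatter). Compound 4 is estimated at 28000 nM, between 10000 nM and 80000 nM.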

Compound 4, concentration for 50% growth inhibition: 12300 nM
Estimate against measurement, compound 4: 2.3-fold (0.36 log units) above; measured number inside the range.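

In this assay, amino in place of chloro on an aromatic carbon again raised the number, giving a 4.0-fold higher number from compound 2 to compound 4 (0.60 log units; beyond the scatter). Set beside the earlier step, the change carries over from the core of compound 1 to the core of compound 2 in direction, and the two sizes cannot be told apart: the same change on two cores in this assay, a 9.8-fold higher number (0.99 log units; beyond the scatter) from compound 1 to compound 3 and a 4.0-fold higher number (0.60 log units; beyond the scatter) from compound 2 to compound 4, 2.5-fold (0.39 log units) apart, within the scatter of two such steps. This rests on two pairs only, so it does not show that the change would behave alike on any other core, nor does it show why the number rises.

The compounds shown leave open how a methylamino or methoxy group would compare with amino and chloro at that carbon. They also leave open what a hydroxymethyl group would do in place of the chloromethyl group that all of them carry.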